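The source may report more compounds than this note shows. Statements on the series, on what has been measured and on what is new or still open speak of the compounds shown alone.

Of the compounds shown here, three sharing one core have so far been measured in an assay on cells for inhibition of Pendrin (Mus musculus), read by fluorescence, with a stated time of 10 min; a higher number here means a weaker inhibitor, a lower number a stronger inhibitor. Compound 1 `Cn1nc(COc2ccc(F)c(F)c2)c2c1CCN(C(=O)Nc1ccc(Cl)cc1)C2` gives 4600 nM in this assay. Compound 2 `Cn1nc(COc2cc(F)cc(F)c2)c2c1CCN(C(=O)NC(=O)c1ccccc1)C2` reaches only the limit of the assay, > 10000 nM in this assay. Compound 3 `CC(C)NC(=O)N1CCc2c(c(COc3cc(F)cc(F)c3)nn2C)C1` likewise sits at the limit, > 10000 nM in this assay. Among the compounds with values here, the single step between neighbouring measured compounds, a step that the two limits leave unreadable from compound 2 to compound 3, cannot be sized because both of its ends rest on (the limit of > 10000 nM in this assay, at which 2 of the 3 values shown sit). Compound 3 therefore stands only as a limit; of the three values shown, two are limits and one, that of compound 1, is a number.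

Compound 4 `CCN(CC)S(=O)(=O)N1CCc2c(c(COc3cc(F)cc(F)c3)nn2C)C1` differs from compound 3 in one place: diethylsulfamoyl in place of isopropylcarbamoyl on an amine nitrogen in a ring. Within the data shown here, no measured step bears on this exchange on the amine nitrogen in a ring, and the only known step, a step that the two limits leave unreadable from compound 2 to compound 3, is itself unreadable. Compound 4 is therefore expected to give about 12000 nM in this assay, within 3000 nM to 40000 nM, most likely reported again only as a limit. The estimated step this implies is a step that the limit leaves unreadable from compound 3 to compound 4, expected to stay within the scatter.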

Compound 4, half-maximal inhibitory concentration: > 10000 nM
Compound 4: a limit, no number; the forecaster's own chance of this, stated with the estimate: 70%; the middle value lies beyond the limit too.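

In this assay compound 4 gives > 10000 nM, which is a limit and not a number, so no step can be read between compound 3 and compound 4: the limit of > 10000 nM in this assay, at which 3 of the 4 values shown sit.

The compounds shown leave open whether diethylsulfamoyl and isopropylcarbamoyl differ at all on the amine nitrogen in a ring.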